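Replacing iodo with methoxy in compound 2

The compounds below may be only part of what the source reports. "The series", "measured", "known", "first", "only" and "open" are said of these compounds alone.

In a functional assay on K562 cells (Homo sapiens) for inhibition, read by trypan blue exclusion, with a stated time of 24 h, tested at 10 uM (a higher number here means more inhibition of growth at the concentration tested, a lower number less inhibition of growth), compound 1 `NC(=O)c1cc(I)ccc1NC(=O)COc1ccccc1` gives 73%, while compound 2 `Cc1ccc(OCC(=O)Nc2ccc(I)cc2C(N)=O)cc1` gives 49.8%, the lower of the two numbers. Among the compounds with values here, the one measured step, a number 23.2 percentage points lower from compound 1 to compound 2 (beyond the scatter), is methyl in place of hydrogen on an aromatic carbon. Compound 3 `COc1ccc(NC(=O)COc2ccc(C)cc2)c(C(N)=O)c1` instead has methoxy in place of iodo on an aromatic carbon. Within the data shown here, no measured step covers this swap, so the earlier step offers only a rough guide to size. A modest fall is tentatively expected, with an estimated step of a number 17.8 percentage points lower from compound 2 to compound 3 (beyond the scatter). For compound 3 the estimate is 32%, within an expected range of 10% to 55%.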

Compound 3, percent growth inhibition at one concentration: 48.1%
Estimate against measurement, compound 3: 16.1 percentage points below, within the range that was stated.
By their numbers in this assay, from the lowest: compounds 3 and 2 (each within the scatter of the next); then compound 1.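

In this assay, exchanging iodo for methoxy gives a number 1.7 percentage points lower from compound 2 to compound 3 (within the scatter), so on this aromatic carbon, para to a large group, the two groups cannot be told apart. Unlike the methyl step, this exchange of one iodine atom for two heavy atoms and one hydrogen-bond acceptor leaves the read-out within the usual scatter. No measured evidence on why accompanies this result.

As far as these compounds go, it remains open whether an amine or a carboxylic acid on this carbon would also keep the number. From the compounds shown here alone, it is equally open whether the same exchange would hold in compound 1, which lacks the methyl.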